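From dimethylamino to (piperidin-1-yl)methyl on a biaryl ester

The source may report more compounds than this note shows. Statements on the series, on what has been measured and on what is new or still open speak of the compounds shown alone.

Compound 1 `CCOC(=O)c1ccnc(-c2ccc(OCC)cc2)c1`: in an assay on COS-7 cells for inhibition of patatin-like phospholipase domain-containing protein 2 (Mus musculus) (on this read-out lower numbers stand for stronger inhibition and higher numbers for weaker inhibition), compound 1 gives 80000 nM
Compound 2 `CCOC(=O)c1cccc(-c2ccc(N(C)C)cc2)c1`: in this assay compound 2 gives 40000 nM
Compound 3 `CCOC(=O)c1cccc(-c2ccncc2)c1`: in this assay compound 3 gives only a limit of the assay, > 200000 nM

Compound 2 holds the lower of the two numbers, with compound 1 close by; the gap between the two lies within the usual scatter, so no order can be read from it. Compound 3 sits at a limit of the assay (the limit of > 200000 nM in this assay, at which 1 of the 3 values shown sits).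

Compound 4 `CCOC(=O)c1cccc(-c2ccc(CN3CCCCC3)cc2)c1` has not yet been measured. It differs from compound 2 in one place: (piperidin-1-yl)methyl in place of dimethylamino on an aromatic carbon. Among the compounds with values here, no measured pair shows the effect of such a change here, so the expectation is a shift no larger than the scatter, in either direction. Compound 4 is therefore expected near 30000 nM, between 8000 nM and 150000 nM. That estimate corresponds to a step of a 1.3-fold lower number from compound 2 to compound 4 (0.12 log units; within the scatter).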

Compound 4, half-maximal inhibitory concentration: 75000 nM
Compound 4: middle estimate off by 2.5-fold (0.40 log units), on the low side, and the stated range covers the measured number.
By their numbers in this assay, from the lowest: compounds 2, 4 and 1 (each within the scatter of the next). At a limit, above all of these: compound 3.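

In this assay, (piperidin-1-yl)methyl in place of dimethylamino on this aromatic carbon, para to a large group, gives only a small step (a 1.9-fold higher number from compound 2 to compound 4 (0.27 log units; within the scatter)). Within the data shown here, this position therefore takes a larger substituent carrying a six-membered non-aromatic ring without a change beyond the scatter, which the earlier compounds could not show. Nothing shown accounts for the size of this step.

From the compounds shown here alone, whether a primary amine or a carboxylic acid on this aromatic carbon would move the number beyond the scatter stays open. So does the effect of a longer chain between the aromatic ring and the piperidine nitrogen.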